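Substituent changes at one ring position of the shared core

The compounds below may be only part of what the source reports. "The series", "measured", "known", "first", "only" and "open" are said of these compounds alone.

compound 1 `CCC(CC)(CC(=O)Nc1cccc(OCc2ccc3ccc(Br)cc3n2)c1)C(=O)O`: 4 nM
compound 2 `CCC(CC)(CC(=O)Nc1cccc(OCc2ccc3ccc(C)cc3n2)c1)C(=O)O`: 11 nM
compound 3 `CCC(CC)(CC(=O)Nc1cccc(OCc2ccc3ccc(OC)cc3n2)c1)C(=O)O`: 80 nM; 80 nM (2 entries)

Three compounds of the series have been run in a functional assay on ileum (Cavia porcellus) for antagonist activity at cysteinyl leukotriene receptor (Homo sapiens); on this read-out lower numbers stand for stronger inhibition and higher numbers for weaker inhibition. Compound 2 gives the higher of the two single numbers; its nearest neighbour is compound 1, and the measured step is a 2.8-fold higher number from compound 1 to compound 2 (0.44 log units; beyond the scatter), a modest move. Going by the values given here, compound 3, with methoxy at the same place, carries two entries, both at the same level, and no single step is worked out for it against compound 2; its two values simply sit well above the number for compound 2.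

Compound 4 `CCC(CC)(CC(=O)Nc1cccc(OCc2ccc3ccc(C(C)=O)cc3n2)c1)C(=O)O` is not yet measured. Its change against compound 2 is acetyl in place of methyl on an aromatic carbon. Among the compounds with values here, the only measured step that touches this position, a 2.8-fold higher number from compound 1 to compound 2 (0.44 log units; beyond the scatter), swaps bromo for methyl; no step exchanges methyl for a group that brings a hydrogen-bond acceptor. The closest hint is compound 3, where a group holding an oxygen at this place gives 80 nM; 80 nM (2 entries). On that basis a modest rise in this assay is expected, of about a 2.3-fold higher number from compound 2 to compound 4 (0.36 log units; beyond the scatter). Compound 4 is therefore estimated at 25 nM, with a range from 6 nM to 100 nM.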

Compound 4, half-maximal inhibitory concentration: 2500 nM
Beside the measured number, compound 4's estimate is 100-fold (2.00 log units) below it, outside the stated range (above it).
By their numbers in this assay, from the lowest: compound 1; then compound 2; then compound 4.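

In this assay acetyl in place of methyl gives a 230-fold higher number from compound 2 to compound 4 (2.36 log units; beyond the scatter) and acetyl in place of bromo gives a 630-fold higher number from compound 1 to compound 4 (2.80 log units; beyond the scatter) so this position can carry a large loss, far beyond the modest move seen between bromo and methyl. The oxygen of a substituent does not by itself set the level here: compound 3 gives 80 nM; 80 nM (2 entries) while compound 4 gives 2500 nM and these printed values lie far apart although both groups hold oxygen. No measurement on hand explains why acetyl costs so much at this position.

Acetyl differs from methyl by both added heavy atoms and a hydrogen-bond acceptor, and these compounds do not separate the two contributions. An ethyl or isopropyl group would test added carbon without oxygen, while a nitrile, an amine or a carboxylic acid would show how far the loss extends to other groups on this aromatic carbon.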